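A few compounds are considered here, and "the series" means these few. Any claim that something is new, unique, unknown or untested is made for them only; others in the source may bear on it.

Compound 1 `COc1ccc(/C=N/Nc2nc(C)cs2)cc1` is the starting point; in an assay on mitochondria for inhibition of Amine oxidase [flavin-containing] A (Bos taurus) (on this read-out higher numbers stand for weaker inhibition and lower numbers for stronger inhibition), compound 1 gives 19.1 nM. Compound 2 `COc1ccc(/C=N/Nc2nc(-c3ccccc3)cs2)cc1` differs from it by phenyl in place of methyl on an aromatic carbon, and in this assay compound 2 gives 50.1 nM. The step of a 2.6-fold higher number from compound 1 to compound 2 (0.42 log units; beyond the scatter) is therefore modest. Compound 3 `Cc1csc(/N=C/c2ccccc2C)n1` is built on a different core, and the difference between the two cores is not broken down here; in this assay compound 3 gives 35.5 nM. Compound 4 `Cc1ccccc1/C=N/c1nc(-c2ccccc2)cs1` has not yet been measured and differs from compound 3 by phenyl in place of methyl on an aromatic carbon. This is the same kind of change as before, though here the ring atom two ring bonds away bears a group of 9 heavy atoms rather than a large group. For compound 4 a step of similar size, a 2.4-fold higher number from compound 3 to compound 4 (0.38 log units; beyond the scatter), is expected. That expectation rests on the step of a 2.6-fold higher number from compound 1 to compound 2 (0.42 log units; beyond the scatter). Compound 4 is thus estimated at 85 nM, within a range from 35 nM to 200 nM.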

Compound 4, inhibition constant: 66.1 nM
Estimate against measurement, compound 4: 1.3-fold (0.11 log units) above; low and high end bracket the measured number.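

In this assay, phenyl in place of methyl on the core of compound 3 gives a 1.9-fold higher number from compound 3 to compound 4 (0.27 log units; within the scatter), so on this core alone the step cannot be told apart from the ordinary spread of repeated measurements. Set beside the earlier step, the change carries over from one core to the other with no difference that the data can resolve: the same change on two cores in this assay, a 2.6-fold higher number (0.42 log units; beyond the scatter) from compound 1 to compound 2 and a 1.9-fold higher number (0.27 log units; within the scatter) from compound 3 to compound 4, 1.4-fold (0.15 log units) apart, within the scatter of two such steps This agreement rests on just two pairs of compounds, so it does not show that the step would hold on other cores, nor does it say why the two cores agree.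

Among the compounds shown, only methyl and phenyl sit at this place on the five-membered ring. On these data alone, how an amine, a carboxylic acid or a longer chain there would read in this assay remains open.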